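The compounds below may be only part of what the source reports. "The series", "measured", "known", "first", "only" and "open" are said of these compounds alone.

Compound 1 `COc1cc2ncnc(-n3nc(-c4ccccn4)nc3N)c2cc1N`: > 40000 nM
Compound 2 `COc1cc2ncnc(-n3nc(-c4ccccn4)nc3N)c2cc1OCCCN1CC(C)OC(C)C1`: 1600 nM

In an assay on MCF7 cells for inhibition of Serine-protein kinase ATM (Homo sapiens), read by immunofluorescence, with a stated time of 1 h (a lower number here means a stronger inhibitor, a higher number a weaker inhibitor), compound 1 gives > 40000 nM, which is a limit of the assay and not a number (the limit of > 40000 nM in this assay, at which 1 of the 2 values shown sits). In this assay, within the data shown here, compound 2 gives 1600 nM, the only real number among the two values shown. Among the measured compounds shown here, the single measured step, an at least 25-fold lower number from compound 1 to compound 2 (1.39 log units; beyond the scatter), shows that exchanging the group on the aromatic carbon can move the reading a great deal. Compound 3 `CCN(CC)C(=O)COc1cc2c(-n3nc(-c4ccccn4)nc3N)ncnc2cc1OC` has not been measured; it differs from compound 2 in that (diethylcarbamoyl in place of 2-(2,6-dimethylmorpholin-4-yl)ethyl on a saturated chain carbon bound to an oxygen on an aromatic ring). For the measured compounds named here, no measured step covers this exact exchange; the one step known only shows that a longer side chain in this place beats a bare amino group. A modest weakening is expected, so the estimated step is a 2.2-fold higher number from compound 2 to compound 3 (0.34 log units; beyond the scatter). Compound 3 is therefore estimated at 3500 nM, with a likely range from 900 nM to 15000 nM.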

Compound 3, half-maximal inhibitory concentration: 5300 nM
The estimate for compound 3 lay 1.5-fold (0.18 log units) below the measured number; the measured number falls inside the stated range.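

The gain over a bare amino group does not depend on the ring-bearing 3-(2,6-dimethylmorpholin-4-yl)propoxy group: with (diethylcarbamoyl)methoxy in that place, the data show an at least 7.5-fold lower number from compound 1 to compound 3 (0.87 log units; beyond the scatter). The exchange between these two side chains still matters, giving a 3.3-fold higher number from compound 2 to compound 3 (0.52 log units; beyond the scatter), so this place accepts quite different groups but does not treat them alike. From the compounds shown here alone, compound 1 gives a limit of the assay and not a number, so the true size of the gain over the amino group stays unknown: the limit of > 40000 nM in this assay, at which 1 of the 3 values shown sits.

The two side chains differ at once in length, in the ring and in the carbonyl, so the compounds shown cannot separate these changes. Going by these compounds, it also remains open how a plain dimethylamino group at the end of the propoxy chain, or a carboxylic acid there, would read.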